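Working notes on four analogues at acid-sensing ion channel 3

This account rests on a few compounds, and the source may have more. Where it says the series, first, only, none or still open, it means among the compounds named here.

Four compounds share one core and differ only in the substituent on the aromatic carbon that carries the variable amine. Compound 1 is `CC(C)(C)Nc1nc(N)c(C(=O)N=C(N)N)nc1Cl`, compound 2 is `CCCN(C)c1nc(N)c(C(=O)N=C(N)N)nc1Cl`, compound 3 is `CN(c1nc(N)c(C(=O)N=C(N)N)nc1Cl)C1CCCCC1` and compound 4 is `NC(N)=NC(=O)c1nc(Cl)c(Nc2ccccc2)nc1N`.

Within the data shown here, of the three compounds already tested, only one carries a number. In an assay for inhibition of acid-sensing ion channel 3 (Homo sapiens), read by patch clamp, tested at 1 uM (on this read-out higher numbers stand for more inhibition at the one concentration tested (going by the name of the read-out) and lower numbers for less inhibition), compound 2 gives 32%. For compound 1 the result in this assay is "not determined" (no result reported), and for compound 3 the result in this assay is likewise "not determined" (no result reported). Among the measured compounds shown here, compound 2 therefore stands alone as the sole numerical reference point, and no step between two measured compounds can be drawn from the series as it stands.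

Compound 4 is the next entry to be measured in this assay. Against compound 2 its structure differs in one place: anilino in place of methyl(propyl)amino on an aromatic carbon.

For the measured compounds named here, with no measured step to lean on, the direction of this change cannot be read from the data. The step of a number 2 percentage points lower from compound 2 to compound 4 (within the scatter) is expected to stay within the usual scatter, with no clear shift in either direction. Compound 4 is estimated at 30% in this assay, within a range from 5% to 60%.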

Compound 4, a percentage reported as inhibition, at one concentration (the size of the read-out at that concentration, not a potency): 44%
Compound 4: the middle estimate sits 14 percentage points below what was measured, and the stated range covers the measured number.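

In this assay, among these compounds, the replacement gives a number 12 percentage points higher from compound 2 to compound 4 (beyond the scatter) and so provides the first measured step: this aromatic carbon, ortho to a chloro group, can carry a six-membered aromatic ring of carbon only with inhibition retained and somewhat raised at the one concentration tested. The change is not a single variation, since anilino brings the ring and 1 hydrogen-bond donor where methyl(propyl)amino has no ring and 0 hydrogen-bond donors, and this one step cannot separate the two differences. No measurement bears on why inhibition rises, so the step stands here as an observation only.

Steps involving compound 1 and compound 3 cannot be read, which leaves the effect of the tert-butylamino and methyl(cyclohexyl)amino groups on this read-out unknown. Also open, going by these compounds, is whether the ring or the amine hydrogen accounts for the step, a question that methyl(phenyl)amino would address directly, while benzylamino or a methoxy group on the anilino ring would show how far the position accepts further extension.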